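This account rests on a few compounds, and the source may have more. Where it says the series, first, only, none or still open, it means among the compounds named here.

Measured so far in a functional assay on the whole organism with Mus musculus as the target, in the maximal electroshock model; a lower number here means that less compound is needed, a higher number that more compound is needed for the effect:

compound 1 `O=C(CCC(=O)c1cccs1)NCCCO`, for which compound 1 gives > 300 mg/kg, a limit of the assay rather than a number
compound 2 `O=C1CCC2(c3ccc(F)cc3)OCCCN12`, for which compound 2 gives 68.7 mg/kg
compound 3 `O=C(CCC(=O)c1ccc(F)cc1)NCCCO`, for which compound 3 gives > 400 mg/kg, again a limit rather than a number

Compound 2 is therefore the only one of the three with a real dose in this assay; the other two results are limits, so nothing can be said about their size relative to it. Compound 4 `O=C1CCC2(c3ccc(Cl)cc3)OCCCN12` has not yet been measured. It differs from compound 2 by chloro in place of fluoro on an aromatic carbon. Within the data shown here, no measured step of this kind exists among the three compounds to show how large such a change tends to be. The expected step of a 1.2-fold lower number from compound 2 to compound 4 (0.10 log units; within the scatter) is small, within the usual scatter, with no clear direction. Compound 4 is thus estimated at 55 mg/kg, with a range from 20 mg/kg to 150 mg/kg.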

Compound 4, dose for half-maximal effect: 58 mg/kg
Compound 4: the middle estimate sits 1.1-fold (0.02 log units) below what was measured; measured number inside the range.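

In this assay chloro in place of fluoro on this aromatic carbon gives a 1.2-fold lower number from compound 2 to compound 4 (0.07 log units; within the scatter) and so the two compounds cannot be told apart. Among these compounds, this is the first measured step at this position, and both compounds give a real dose rather than a limit of the assay, so either halogen is tolerated here. Nothing shown explains why this exchange changes so little.

Going by these compounds, what a methoxy group, an amine or a carboxylic acid at this position would do remains open, as does whether any group here can move the dose beyond the scatter.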